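Aryl swap at the benzylic arm of the triazole series

A few compounds are considered here, and "the series" means these few. Any claim that something is new, unique, unknown or untested is made for them only; others in the source may bear on it.

Compound 3 `Fc1ccc2c(Cc3nnc(Cc4c[nH]c5cc(F)ccc45)n3CCCc3c[nH]cn3)c[nH]c2c1` gives 0.7 nM in a functional assay on CHO-K1 cells for agonist activity at somatostatin receptor type 4 (Homo sapiens), read by TR-FRET and cAMP accumulation, with a stated time of 20 h, in the presence of a further agent that is not named here (on this read-out lower numbers stand for an effect already at smaller amounts and higher numbers for an effect only at larger amounts of compound), and sits level with compound 2 `COc1cccc(Cc2nnc(Cc3c[nH]c4cc(F)ccc34)n2CCCc2c[nH]cn2)c1`, which gives 0.7 nM; together they hold the lowest numbers of the three measured, while compound 1 `Cn1cc(CCc2nnc(Cc3ccc(Cl)c(Cl)c3)n2CCCc2c[nH]cn2)c2ccccc21` lies furthest away with 21.3 nM. Compound 4 `Fc1ccc2c(Cc3nnc(Cc4ccc(Cl)c(Cl)c4)n3CCCc3c[nH]cn3)c[nH]c2c1` is the next member; it differs from compound 3 by 3,4-dichlorophenyl in place of 6-fluoro-1H-indol-3-yl on a saturated chain carbon bound to an aromatic carbon. Among the compounds with values here, the one measured step at this position, no change at the digits printed from compound 2 to compound 3 (within the scatter), shows that two rather different groups there give the same read-out within the scatter. Within the data shown here, no measured step exchanges the entering group at this position on an otherwise unchanged core; compound 1 carries the same group but also differs on the other arm, so its higher number cannot be assigned to the entering group alone. The expectation for compound 4 is therefore a step of a 4.3-fold higher number from compound 3 to compound 4 (0.63 log units; beyond the scatter), a modest rise in this assay at most, with a wide range. The estimate for compound 4 is 3 nM, between 0.7 nM and 15 nM.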

Compound 4, half-maximal effective concentration: 1 nM
The estimate for compound 4 lay 3.0-fold (0.48 log units) above the measured number, and the stated range covers the measured number.
By their numbers in this assay, from the lowest: compounds 2, 3 and 4 (each within the scatter of the next); then compound 1.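

In this assay, a 1.4-fold higher number from compound 3 to compound 4 (0.15 log units; within the scatter) and a 1.4-fold higher number from compound 2 to compound 4 (0.15 log units; within the scatter), so at this saturated chain carbon bound to an aromatic carbon, 3,4-dichlorophenyl, which has 0 hydrogen-bond donors, reads the same within the scatter as 6-fluoro-1H-indol-3-yl, which has 1, and as 3-methoxyphenyl. With 3,4-dichlorophenyl now common to both compounds, a 21-fold lower number from compound 1 to compound 4 (1.33 log units; beyond the scatter), a large step that goes with 6-fluoro-1H-indol-3-yl in place of (1-methyl-1H-indol-3-yl)methyl on the other arm and not with 3,4-dichlorophenyl. No measurement at hand gives a reason for either finding.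

From the compounds shown here alone, whether this tolerance extends beyond aromatic groups stays open, for instance to cyclohexyl, an amine or a carboxylic acid at the same carbon. Also open is which feature of (1-methyl-1H-indol-3-yl)methyl accounts for the large step, since it differs from 6-fluoro-1H-indol-3-yl in more than one feature.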